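A few compounds are considered here, and "the series" means these few. Any claim that something is new, unique, unknown or untested is made for them only; others in the source may bear on it.

Compound 1 `CCNC(=O)Nc1nc2cc(-c3cnc(C(C)(C)O)nc3)cc(-c3cc(CN4CCC(C)(O)C4)ccn3)c2s1`: 0.194
Compound 2 `CCNC(=O)Nc1nc2cc(-c3cnc(C(C)(C)O)nc3)cc(-c3cc(CNC4CC4)ccn3)c2s1`: 0.056

Among the measured compounds shown here, in an ADME assay on a cell-free system (plasma, Mus musculus) for protein binding, using ultracentrifugation (on this read-out higher numbers stand for a larger free fraction and lower numbers for a smaller free fraction), compound 2 gives 0.056, the lower of the two numbers so far. Compound 3 `CCNC(=O)Nc1nc2cc(-c3cnc(C(C)(C)O)nc3)cc(-c3cc(CN4CC(O)C4)ccn3)c2s1` has 3-hydroxyazetidin-1-yl in place of cyclopropylamino on a saturated chain carbon bound to an aromatic carbon. For the measured compounds named here, only one measured step bears on this, a 3.5-fold lower number from compound 1 to compound 2 (0.54 log units; beyond the scatter), which replaced a hydroxy-bearing ring, 3-hydroxy-3-methylpyrrolidin-1-yl, with cyclopropylamino. The new change runs the other way, so a rise of similar size is expected, with the estimated step being a 2.9-fold higher number from compound 2 to compound 3 (0.46 log units; beyond the scatter). For compound 3 the estimate is 0.16, with an expected range of 0.08 to 0.3.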

Compound 3, unbound fraction: 0.22
Beside the measured number, compound 3's estimate is 1.4-fold (0.14 log units) below it, and the stated range covers the measured number.
By their numbers in this assay, from the lowest: compound 2; then compounds 1 and 3 (each within the scatter of the next).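

Putting 3-hydroxyazetidin-1-yl in place of cyclopropylamino on this saturated chain carbon gives a 3.9-fold higher number from compound 2 to compound 3 (0.59 log units; beyond the scatter) in this assay. The two hydroxy-bearing rings read alike, with a 1.1-fold higher number from compound 1 to compound 3 (0.05 log units; within the scatter), so a second ring of this kind, with a different ring size, also stands apart from cyclopropylamino. No measurement shown here explains why this change moves the number. Still open, going by these compounds, is how plain azetidin-1-yl, with no hydroxy group, would read at this place, which would help separate the effect of the hydroxy group from that of the ring. On these data alone, a morpholin-4-yl group at the same place is equally open.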